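A few compounds are considered here, and "the series" means these few. Any claim that something is new, unique, unknown or untested is made for them only; others in the source may bear on it.

Compound 1 `C=C1[C@H](O)[C@@H](OC(=O)C(C)(C)C)[C@@H](O)C(C)(C)/C=C/[C@H](C)[C@H](OC(=O)c2ccccc2)[C@@]2(O)C[C@@](C)(O)[C@H](OC(C)=O)[C@@H]2[C@H]1OCC(C)C`: > 100000 nM
Compound 2 `C=C1[C@H](O)[C@@H](OC(=O)c2cccc(C)c2)[C@@H](O)C(C)(C)/C=C/[C@H](C)[C@H](OC(=O)c2ccccc2)[C@@]2(O)C[C@@](C)(O)[C@H](OC(C)=O)[C@@H]2[C@H]1OCC(C)C`: 75200 nM
Compound 3 `C=C1[C@H](OC(C)=O)[C@@H](OC(=O)C(C)(C)C)[C@@H](OC(C)=O)C(C)(C)/C=C/[C@H](C)[C@H](OC(=O)c2ccccc2)[C@@]2(O)C[C@@](C)(O)[C@H](OC(C)=O)[C@@H]2[C@H]1OCC(C)C`: > 100000 nM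

Of the compounds shown here, three have been tested in a functional assay on NCI/ADR-RES cells (Homo sapiens) for antiproliferative activity, read by MTT assay, with a stated time of 48 h; on this read-out lower numbers stand for stronger inhibition and higher numbers for weaker inhibition. For compound 1 the assay reports > 100000 nM, which is a limit rather than a number. Compound 2 carries a single change relative to it (3-methylphenyl in place of tert-butyl on a carbonyl carbon); in this assay compound 2 gives 75200 nM. The step that this change made is an at least 1.3-fold lower number from compound 1 to compound 2 (0.12 log units; that floor lies within the scatter). For compound 3 the assay again reports only a limit, > 100000 nM. How the core of compound 3 differs from the core of compound 1 is not broken down here. Of the three values shown, two sit at the same limit (the limit of > 100000 nM in this assay, at which 2 of the 3 values shown sit).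

Compound 4 `C=C1[C@H](OC(C)=O)[C@@H](OC(=O)c2cccc(C)c2)[C@@H](OC(C)=O)C(C)(C)/C=C/[C@H](C)[C@H](OC(=O)c2ccccc2)[C@@]2(O)C[C@@](C)(O)[C@H](OC(C)=O)[C@@H]2[C@H]1OCC(C)C` has not yet been measured. It differs from compound 3 by the same change (3-methylphenyl in place of tert-butyl on a carbonyl carbon), at the same kind of place. The step from compound 3 to compound 4 is expected to be an at least 1.1-fold lower number from compound 3 to compound 4 (0.04 log units; that floor lies within the scatter), beside the earlier one. That expectation rests on compound 3, whose result is the limit > 100000 nM. It also rests on the step of an at least 1.3-fold lower number from compound 1 to compound 2 (0.12 log units; that floor lies within the scatter), whose floor lies within the usual scatter. Compound 4 is therefore estimated at 90000 nM, between 40000 nM and 200000 nM, with a fair chance that only a limit is reported.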

Compound 4, half-maximal inhibitory concentration: > 100000 nM
Compound 4: a limit, no number (the forecaster's own chance of this, stated with the estimate: 55%); middle value at least 1.1-fold (0.04 log units) from the limit.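

In this assay compound 4 gives > 100000 nM, which is a limit and not a number. Compound 3 also stands at a limit, so the step between compound 3 and compound 4 cannot be read. The compounds shown leave open whether 3-methylphenyl in place of tert-butyl on a carbonyl carbon changes the read-out on the core of compound 3, and most values give no number: the limit of > 100000 nM in this assay, at which 3 of the 4 values shown sit.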